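Imidazolyl tetralin sulfonamides: positional isomer check

A few compounds are considered here, and "the series" means these few. Any claim that something is new, unique, unknown or untested is made for them only; others in the source may bear on it.

Compounds measured in an assay on isolated protein for binding affinity to Alpha-1A adrenergic receptor (Rattus norvegicus), read by radioligand binding; a lower number here means a stronger inhibitor, a higher number a weaker inhibitor:
- compound 1 `COc1ccc2c(c1NS(C)(=O)=O)CCCC2c1c[nH]cn1`: 501 nM
- compound 2 `CCS(=O)(=O)Nc1cc(Cl)cc2c1CCCC2c1c[nH]cn1`: 45.7 nM
- compound 3 `Cn1cnc(C2CCCc3c(NS(C)(=O)=O)cccc32)c1`: 275 nM

Among the three numbers from this assay, compound 3 has the second highest. Its nearest neighbour is compound 1, whose value lies within the scatter of that of compound 3, so the two cannot be told apart. Compound 2 stands well away on the lower side, beyond the scatter, and is the only one of the three that clearly separates from the rest.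

Compound 4 `Cn1cncc1C1CCCc2c(NS(C)(=O)=O)cccc21` has not yet been measured. It differs from compound 3 in one respect: 1-methyl-1H-imidazol-5-yl in place of 1-methyl-1H-imidazol-4-yl on a saturated ring carbon. The two share every atom and differ only in how the methylated ring is joined to the saturated ring carbon.

Among the measured compounds shown here, no pair of measured compounds differs in this way, so the size of the step is not known from the series. The expectation is a moderate step toward a higher number, since compound 3 itself gives 275 nM and the shifted attachment is taken as unfavourable rather than neutral. The estimated step from compound 3 to compound 4 in this assay is a 2.9-fold higher number from compound 3 to compound 4 (0.46 log units; beyond the scatter). For compound 4 the estimate in this assay is 800 nM, with a range from 250 nM to 2500 nM.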

Compound 4, inhibition constant: < 10000 nM
Compound 4: no number, only a limit (the forecaster's own chance of this, stated with the estimate: 5%); the middle value is on the limit's open side.
By their numbers in this assay, from the lowest: compound 2; then compounds 3 and 1 (each within the scatter of the next).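

In this assay, among the compounds shown here, compound 4 gives < 10000 nM, which is a limit of the assay and not a number, so no step from compound 3 to compound 4 can be read. The compounds shown leave open what 1-methyl-1H-imidazol-5-yl in place of 1-methyl-1H-imidazol-4-yl does to the number.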